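From 2-hydroxyphenyl to 4-hydroxyphenyl: working notes on the series

A few compounds are considered here, and "the series" means these few. Any claim that something is new, unique, unknown or untested is made for them only; others in the source may bear on it.

Measured so far in a functional assay on SNB-19 cells (Homo sapiens) for inhibition, read by sulforhodamine B assay, with a stated time of 48 h; on this read-out lower numbers stand for stronger inhibition of growth and higher numbers for weaker inhibition of growth
- compound 1 `O=C(Cc1csc2nc(-c3ccc(Br)cc3)cn12)N/N=C/c1ccccc1` gives 43700 nM
- compound 2 `O=C(Cc1csc2nc(-c3ccc(Br)cc3)cn12)N/N=C/c1ccccc1O` gives 6760 nM

Compound 2 holds the lower of the two numbers, 6760 nM, in this assay. Next is compound 3 `O=C(Cc1csc2nc(-c3ccc(Br)cc3)cn12)N/N=C/c1ccc(O)cc1`, where the change is 4-hydroxyphenyl in place of 2-hydroxyphenyl on a carbon with a double bond to nitrogen. For the measured compounds named here, the only measured step bearing on this is a 6.5-fold lower number from compound 1 to compound 2 (0.81 log units; beyond the scatter), which is modest and beyond the scatter. It covers the 2-hydroxyphenyl only, and no 4-hydroxyphenyl has been measured. The expected change is modest and upward, a 1.8-fold higher number from compound 2 to compound 3 (0.25 log units; within the scatter), with the number still under that of the unsubstituted phenyl. For compound 3 the estimated value is 12000 nM, with an expected range of 4000 nM to 40000 nM.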

Compound 3, concentration for 50% growth inhibition: 57500 nM
For compound 3 the middle estimate is 4.8-fold (0.68 log units) below the measured one, and the stated range ends below it.
By their numbers in this assay, from the lowest: compound 2; then compounds 1 and 3 (each within the scatter of the next).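

In this assay the effect of the hydroxy depends on where it sits, and the shift to the 4-hydroxyphenyl gives an 8.5-fold higher number from compound 2 to compound 3 (0.93 log units; beyond the scatter). Hydroxy in place of hydrogen gives a 1.3-fold higher number from compound 1 to compound 3 (0.12 log units; within the scatter) when it forms the 4-hydroxyphenyl, so the gain seen so far belongs to the 2-hydroxyphenyl alone. Nothing at hand accounts for the difference between these two groups.

Going by these compounds, it remains open whether a methoxy or an amine in place of the hydroxy of the 2-hydroxyphenyl would keep the lower number of compound 2.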